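Methoxy for methyl on the carbonyl: four-compound whole-animal notes

The compounds below may be only part of what the source reports. "The series", "measured", "known", "first", "only" and "open" are said of these compounds alone.

Measured so far:
Compound 1 `CC(=O)NCC#CCn1cncc1C`, in a functional assay on the whole organism for antagonist activity, with Mus musculus as the target (on this read-out lower numbers stand for an effect already at smaller amounts and higher numbers for an effect only at larger amounts of compound), compound 1 gives > 100 mg/kg, a limit of the assay and not a number.
Compound 2 `CC(=O)N(C)CC#CCN1CCCC1`, in this assay compound 2 gives > 10 mg/kg, a limit of the assay and not a number.
Compound 3 `COC(=O)NCC#CCn1cncc1C`, in this assay compound 3 gives > 100 mg/kg, a limit of the assay and not a number.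

Compound 3 arises from compound 1 by methoxy in place of methyl on a carbonyl carbon. The step that the two limits leave unreadable from compound 1 to compound 3 cannot be sized, since both ends of it are limits: the limit of > 100 mg/kg in this assay, at which 2 of the 3 values shown sit. Among the compounds with values here, the only other point in the set is the limit of > 10 mg/kg in this assay, at which 1 of the 3 values shown sits, which belongs to compound 2 and is a limit as well, so no measured step anywhere in this assay carries a readable size.

Compound 4 `COC(=O)N(C)CC#CCN1CCCC1` is not yet measured. It arises from compound 2 by methoxy in place of methyl on a carbonyl carbon. The place line around this change is the same, word for word, as that around the change from compound 1 to compound 3, so it is the same change. The difference between the two cores, that of compound 2 and that of compound 1, is not broken down here.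

Taken together, the three measured values show nothing but limits, and the one measured instance of this change sits between two limits. No direction or size can be read off. Compound 4 is therefore expected to behave much like compound 2 in this assay, with the step that the limit leaves unreadable from compound 2 to compound 4 estimated close to nil, and the expectation is that compound 4 may again lie at a limit. The estimate for compound 4 is 40 mg/kg, with a span from 10 mg/kg to 300 mg/kg, an expectation resting only on compound 2 at > 10 mg/kg and on the unreadable step that the two limits leave unreadable from compound 1 to compound 3.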

Compound 4, dose for half-maximal effect: > 10 mg/kg
Compound 4: a limit, no number; the forecaster's own chance of this, stated with the estimate: 80%; the middle value lies beyond the limit too.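

In this assay compound 4 gives > 10 mg/kg, a limit of the assay and not a number. Compound 2 sits at the same limit, so no step from compound 2 to compound 4 can be read: the limit of > 10 mg/kg in this assay, at which 2 of the 4 values shown sit.

The compounds shown leave open whether methoxy in place of methyl on a carbonyl carbon changes this read-out at all, and in which direction.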